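The source may hold more compounds than are shown below. What is called first, only, known or untested is meant among the compounds shown, and "the series" means these compounds.

Measured in a functional assay on SiHa cells (Homo sapiens) for inhibition, read by sulforhodamine B assay; a higher number here means a weaker inhibitor of growth, a lower number a stronger inhibitor of growth:
- compound 1 `Cc1ccc2[nH]c(-c3ccc(-c4ccc(-c5ccc(N(C)C)cc5)cc4)cc3)nc2c1`: 7110 nM
- compound 2 `FC(F)(F)Oc1ccc(-c2ccc(-c3ccc(-c4nc5ccccc5[nH]4)cc3)cc2)cc1`: 38400 nM
- compound 3 `Cc1ccc2[nH]c(-c3ccc(-c4ccc(-c5ccccc5)cc4)cc3)nc2c1`: 35200 nM

Compound 3 sits at the high end of these numbers, within the scatter of compound 2 and clearly apart from compound 1. The next compound, compound 4 `Cc1ccc2[nH]c(-c3ccc(-c4ccc(-c5ccc(OC(F)(F)F)cc5)cc4)cc3)nc2c1`, has trifluoromethoxy in place of hydrogen on an aromatic carbon, para to a large group: trifluoromethoxy in place of hydrogen on an aromatic carbon.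

Going by the values given here, only one measured step touches this spot. It is a 5.0-fold higher number from compound 1 to compound 3 (0.69 log units; beyond the scatter), with hydrogen in place of dimethylamino, so the number can move when this spot changes. That step involves a different group, however, so its size does not carry over. The closer guide is compound 2, which carries trifluoromethoxy on a slightly different core and gives 38400 nM, within the scatter of compound 3. No step beyond the scatter is therefore expected in this assay. The expected change is a 1.1-fold lower number from compound 3 to compound 4 (0.04 log units; within the scatter). For compound 4 the estimated value is 32000 nM, with an expected range of 14000 nM to 60000 nM.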

Compound 4, concentration for 50% growth inhibition: 28300 nM
For compound 4 the middle estimate is 1.1-fold (0.05 log units) above the measured one; the range from low to high includes it.
By their numbers in this assay, from the lowest: compound 1; then compounds 4, 3 and 2 (each within the scatter of the next).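

In this assay, trifluoromethoxy at this spot cannot be told apart from hydrogen, a 1.2-fold lower number from compound 3 to compound 4 (0.09 log units; within the scatter), and the methyl on the core makes just as little difference, a 1.4-fold lower number from compound 2 to compound 4 (0.13 log units; within the scatter). So dimethylamino is what sets compound 1 apart, since the step to trifluoromethoxy, a 4.0-fold higher number from compound 1 to compound 4 (0.60 log units; beyond the scatter), is beyond the scatter and of similar size to the step to hydrogen, and the change at this spot therefore depends on which group enters rather than on any group being there. No measurement here explains this difference between the groups.

As far as these compounds go, it stays open whether a plain amine, a methoxy group or a carboxylic acid at this spot would behave like dimethylamino or like trifluoromethoxy. Also open, from the compounds shown here alone, is whether the methyl on the core would matter as little alongside dimethylamino.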